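A few compounds are considered here, and "the series" means these few. Any claim that something is new, unique, unknown or untested is made for them only; others in the source may bear on it.

Three hydrazones built on the same quinazolinone-bearing core were measured in a physicochemical assay, read by spectrophotometry, with a stated time of 6 min; on this read-out higher numbers stand for weaker inhibition and lower numbers for stronger inhibition. Compound 1 `COc1cc(/C=N/NC(=O)CCCc2nc3ccccc3c(=O)[nH]2)cc(OC)c1O` gives 135000000 nM in this assay, compound 2 `COc1cc(/C=N/NC(=O)CCCc2nc3ccccc3c(=O)[nH]2)cc(O)c1O` gives 50000000 nM, and compound 3 `O=C(CCc1nc2ccccc2c(=O)[nH]1)N/N=C/c1cc(O)c(O)c(O)c1` gives 35000000 nM. Between compound 2 and compound 1 the single change is methyl in place of hydrogen on an oxygen on an aromatic ring, and it produced a 2.7-fold higher number from compound 2 to compound 1 (0.43 log units; beyond the scatter). Compound 3 gives the lowest of the three numbers, but its gap to compound 2 lies within the scatter, so no order between these two can be claimed; its gap to compound 1 lies beyond the scatter. The difference between the cores of compound 3 and compound 2 is not broken down here.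

Compound 4 `COc1cc(/C=N/NC(=O)CCc2nc3ccccc3c(=O)[nH]2)cc(O)c1O` has not been measured. It differs from compound 3 by methyl in place of hydrogen on an oxygen on an aromatic ring, the same change that separates compound 2 from compound 1, at a place described in the same words. On the strength of a 2.7-fold higher number from compound 2 to compound 1 (0.43 log units; beyond the scatter), compound 4 is expected to show a 2.6-fold higher number from compound 3 to compound 4 (0.41 log units; beyond the scatter). Compound 4 is therefore estimated at 90000000 nM, within a range from 40000000 nM to 200000000 nM.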

Compound 4, half-maximal inhibitory concentration: 40000000 nM
Estimate against measurement, compound 4: 2.3-fold (0.35 log units) above, within the range that was stated.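

In this assay the replacement of hydrogen by methyl on an oxygen on an aromatic ring, hydroxy to methoxy, gave a 1.1-fold higher number from compound 3 to compound 4 (0.06 log units; within the scatter) on one core, against a 2.7-fold higher number from compound 2 to compound 1 (0.43 log units; beyond the scatter) on the other, so a step beyond the scatter on the core of compound 2 was not repeated as a readable step on the core of compound 3. This shows that the size of the step did not carry over in full between these two cores, but with one pair on each core it does not show how far the two steps differ from each other, and it gives no rule for any other core. Nothing available here bears on why the two cores gave different readings.

The compounds shown leave open whether an ethyl or benzyl group on that oxygen, or an amine or a carboxylic acid in place of the hydroxy, would give a step beyond the scatter on either core. They also leave open how the same replacement would read on a core with a longer chain.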